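Extending the Imidazole Substituent from Cyclobutyl to Benzyl

The compounds below may be only part of what the source reports. "The series", "measured", "known", "first", "only" and "open" are said of these compounds alone.

Measured compounds:
compound 1 `O=C(O)c1ccccc1-c1ccc(CCc2ncc(CC3CCC3)[nH]2)cc1` — 588 nM
compound 2 `O=C(O)c1ccccc1-c1ccc(CCc2ncc(CC3CCCC3)[nH]2)cc1` — 133 nM
compound 3 `O=C(O)c1ccccc1-c1ccc(CCc2ncc(Cc3ccccc3Cl)[nH]2)cc1` — 292 nM

In an in vitro functional assay on cells for agonist activity at Bombesin receptor subtype-3 (Homo sapiens), read by luminescence and calcium flux (on this read-out higher numbers stand for an effect only at larger amounts of compound and lower numbers for an effect already at smaller amounts), compound 1 gives 588 nM, the highest number of the three; compound 2 is the furthest from it with a 4.4-fold lower number from compound 1 to compound 2 (0.65 log units; beyond the scatter), and compound 3 the nearest with a 2.0-fold lower number from compound 1 to compound 3 (0.30 log units; within the scatter). The unmeasured compound 4 `O=C(O)c1ccccc1-c1ccc(CCc2ncc(CCc3ccccc3)[nH]2)cc1` differs from compound 1 as follows: benzyl in place of cyclobutyl on a saturated chain carbon bound to an aromatic carbon.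

Within the data shown here, two measured steps bear on this change. The replacement of cyclobutyl by 2-chlorophenyl, a 2.0-fold lower number from compound 1 to compound 3 (0.30 log units; within the scatter), stays within the scatter, while the move to the larger saturated ring, a 4.4-fold lower number from compound 1 to compound 2 (0.65 log units; beyond the scatter), gives a modest lowering. Benzyl brings an aromatic ring, as in compound 3, and more heavy atoms than either cyclobutyl or cyclopentyl. A modest lowering of the number is therefore expected, of a size no larger than that seen for compound 2. Compound 4 is expected to give 250 nM in this assay, within 100 nM to 600 nM, which corresponds to an estimated step of a 2.4-fold lower number from compound 1 to compound 4 (0.37 log units; beyond the scatter).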

Compound 4, half-maximal effective concentration: 1320 nM
The estimate for compound 4 lay 5.3-fold (0.72 log units) below the measured number; measured number outside the range, above it.
By their numbers in this assay, from the lowest: compound 2; then compounds 3 and 1 (each within the scatter of the next); then compound 4.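

In this assay, benzyl in place of cyclobutyl on a saturated chain carbon bound to an aromatic carbon gives a 2.2-fold higher number from compound 1 to compound 4 (0.35 log units; beyond the scatter), the first step from compound 1 towards a higher number, so a larger group here does not go with a lower number: compound 2 fits that trend, while compound 4 goes against it. The aromatic ring does not lower the number either, as the other two steps show, a 4.5-fold higher number from compound 3 to compound 4 (0.66 log units; beyond the scatter) and a 9.9-fold higher number from compound 2 to compound 4 (1.00 log units; beyond the scatter), and compound 4 has the highest number of the four. Nothing available explains why the benzyl group behaves this way.

The compounds shown leave open whether the higher number follows the aromatic ring or the longer reach of the group. A cyclopentylmethyl or 2-chlorobenzyl group at this place, or an amine on the benzyl ring, would bear on that.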